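The source may hold more compounds than are shown below. What is called first, only, known or untested is meant among the compounds shown, and "the series" means these compounds.

Measured so far:
- compound 1 `CCN(CC)CCn1cnnc1-c1cc(Oc2ccc(NC(=O)Nc3ccc(F)c(Cl)c3)cc2F)ccn1`: 1.9%
- compound 2 `CN(C)CCCn1cnnc1-c1cc(Oc2ccc(NC(=O)Nc3ccccc3C(F)(F)F)cc2F)ccn1`: "not determined" (no result reported)
- compound 3 `CN(C)CCCn1cnnc1-c1cc(Oc2ccc(NC(=O)Nc3ccc(F)c(F)c3)cc2F)ccn1`: 30.9%

In an assay on isolated protein for inhibition of proto-oncogene tyrosine-protein kinase receptor Ret (Homo sapiens), read by mobility shift assay, with a stated time of 1 h, tested at 10 uM (a lower number here means less inhibition, a higher number more inhibition at the concentration tested (going by the name of the read-out)), compound 1 gives 1.9% and compound 3 gives 30.9%, while for compound 2 no number was reported. Compound 3 therefore stands highest of the two numbers, and its gap to compound 1 lies beyond the usual scatter. Compound 4 `CN(C)CCCn1cnnc1-c1cc(Oc2ccc(NC(=O)Nc3ccc(F)c(Cl)c3)cc2F)ccn1` has not yet been tested. It differs from compound 3 in one place: chloro in place of fluoro on an aromatic carbon. Among the measured compounds shown here, no pair of measured compounds shows this same change, so its size cannot be read off directly. Compound 1 carries the same 3-chloro-4-fluorophenyl group that enters in compound 4 but has a different side chain on the shared core, and it sits low; compound 3 shares everything else with compound 4 and sits higher. A modest drop is expected, a number 12.9 percentage points lower from compound 3 to compound 4 (beyond the scatter), though a result within the scatter of compound 3 would not surprise. For compound 4 the expected value is 18%, with a range from 3% to 36%.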

Compound 4, a percentage reported as inhibition, at one concentration (the size of the read-out at that concentration, not a potency): 45.5%
For compound 4 the middle estimate is 27.5 percentage points below the measured one, and the stated range ends below it.
By their numbers in this assay, from the lowest: compound 1; then compound 3; then compound 4.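

In this assay, chloro in place of fluoro on this aromatic carbon gives a number 14.6 percentage points higher from compound 3 to compound 4 (beyond the scatter), so with the same side chain this position accepts chloro without any loss of inhibition. The low value of compound 1 therefore cannot be pinned on its 3-chloro-4-fluorophenyl group: with that group held fixed, (dimethylamino)methyl in place of diethylamino on the saturated chain carbon gives a number 43.6 percentage points higher from compound 1 to compound 4 (beyond the scatter), a large step that points to the side chain as the place where the two compounds part. No measurement at hand explains why either step goes the way it does.

The compounds shown leave open whether bromo or methyl on the same aromatic carbon would continue this trend. They also leave open how far the side chain matters beyond these two amines, for example with a pyrrolidine or morpholine at its end.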